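A few compounds are considered here, and "the series" means these few. Any claim that something is new, unique, unknown or untested is made for them only; others in the source may bear on it.

Compound 1 `Cc1cc(C)cc(S(=O)(=O)n2c(SCC(=O)Nc3ccccc3Br)nc3ccccc32)c1` is tested in an ADME assay on MT4 cells (Homo sapiens) for cytotoxicity; on this read-out lower numbers stand for higher toxicity in this test and higher numbers for lower toxicity in this test. For compound 1 the result is a limit of the assay, >= 235000 nM, rather than a number. Compound 2 `Cc1cc(C)cc(S(=O)(=O)n2c(SCC(=O)Nc3ccccc3Br)nc3ccc(Cl)cc32)c1` carries the change chloro in place of hydrogen on an aromatic carbon on the same core, and in this assay compound 2 gives 145000 nM. The step of an at least 1.6-fold lower number from compound 1 to compound 2 (0.20 log units; that floor lies within the scatter) rests on that limit, so its true size is not fixed, and the floor it gives lies within the usual scatter.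

Compound 3 `COC(=O)c1ccc(NC(=O)CSc2nc3ccccc3n2Cc2cc(C)cc(C)c2)c(Cl)c1` is built on a different core, and the difference between the two cores is not broken down here. In this assay compound 3 gives 191000 nM; this is the highest of the two numbers shown, and the nearest value, that of compound 2, lies within the scatter of it, so no order between compound 2 and compound 3 can be read from these figures.

Compound 4 `COC(=O)c1ccc(NC(=O)CSc2nc3ccc(Cl)cc3n2Cc2cc(C)cc(C)c2)c(Cl)c1` has not yet been measured in this assay. It differs from compound 3 by chloro in place of hydrogen on an aromatic carbon, the same change that separates compound 1 from compound 2, at a place described in identical words. The expectation for compound 4 rests on the step of an at least 1.6-fold lower number from compound 1 to compound 2 (0.20 log units; that floor lies within the scatter), which gives only a floor within the scatter. It also rests on compound 3 as the starting point, with compound 3 giving 191000 nM. On that basis a step of a 1.3-fold lower number from compound 3 to compound 4 (0.10 log units; within the scatter) is expected. For compound 4 the estimate in this assay is therefore 150000 nM, with a range from 80000 nM to 260000 nM.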

Compound 4, half-maximal cytotoxic concentration: 105000 nM
Estimate against measurement, compound 4: 1.4-fold (0.15 log units) above, within the range that was stated.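

In this assay, chloro in place of hydrogen on an aromatic carbon gives a 1.8-fold lower number from compound 3 to compound 4 (0.26 log units; within the scatter), so on the core of compound 3 the step stays within the usual scatter of repeated measurements. Set beside the earlier step, this shows only that the two readings are compatible; it does not show that the change carries over from one core to the other with a fixed size, nor that it has a real effect on either core: the same change on two cores in this assay, an at least 1.6-fold lower number (0.20 log units; that floor lies within the scatter) from compound 1 to compound 2 and a 1.8-fold lower number (0.26 log units; within the scatter) from compound 3 to compound 4; the limit leaves it open whether they differ The earlier step cannot be sized more closely, since compound 1 stands at a limit of the assay and not at a number: the limit of >= 235000 nM in this assay, at which 1 of the 4 values shown sits.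

The compounds shown leave open whether another group at the same aromatic carbon, such as fluoro, methoxy, an amine or a carboxylic acid, would give a step that clears the scatter in this assay. They also leave open how chloro in place of hydrogen would read on a third core, or on the core of compound 1 if that compound were given a number rather than a limit.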